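The source may report more compounds than this note shows. Statements on the series, on what has been measured and on what is new or still open speak of the compounds shown alone.

- compound 1 `CC#CCn1c(N2CCC[C@@H](N)C2)nc2c1c(=O)n(CCCN1CCC(n3cc(-c4ccccc4)nn3)CC1)c(=O)n2C` gives 19.7% in this test
- compound 2 `CC#CCn1c(N2CCC[C@@H](N)C2)nc2c1c(=O)n(CCCN1CCN(c3noc(-c4ccccc4)n3)CC1)c(=O)n2C` gives 25% in this test

Going by the values given here, in an ADME assay on cells (Hepatocyte, Rattus norvegicus, strain Sprague-Dawley) for metabolic stability, read by LC-MS, with a stated time of 30 min (on this read-out higher numbers stand for a more stable compound and lower numbers for a less stable compound), compound 1 gives 19.7% and lies within the usual scatter of compound 2, the only other measured compound. Compound 3 `CC#CCn1c(N2CCC[C@@H](N)C2)nc2c1c(=O)n(CCCN1CCC(c3nc(-c4ccccc4)c[nH]3)CC1)c(=O)n2C` has not been measured. It differs from compound 1 by carrying 4-phenyl-1H-imidazol-2-yl in place of 4-phenyl-1H-1,2,3-triazol-1-yl on a saturated ring carbon. Among the compounds with values here, no measured pair shows what this swap does, so no step beyond the scatter is expected in this assay in either direction. Compound 3 is expected to give about 20% with an estimated range from 8% to 38% in this measurement. That estimate means a number 0.3 percentage points higher from compound 1 to compound 3 (within the scatter) as the expected step.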

Compound 3, percent of the compound remaining: 21.7%
Compound 3: middle estimate off by 1.7 percentage points, on the low side; low and high end bracket the measured number.
By their numbers in this assay, from the lowest: compounds 1, 3 and 2 (each within the scatter of the next).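

Placing 4-phenyl-1H-imidazol-2-yl in place of 4-phenyl-1H-1,2,3-triazol-1-yl on a saturated ring carbon gives, in this assay, a number 2 percentage points higher from compound 1 to compound 3 (within the scatter). This one-place comparison therefore cannot separate the two groups, even though the entering group carries a hydrogen-bond donor and the leaving group carries none. No supporting data bear on why this is so. Still open, as far as these compounds go, is whether a group of a different kind on this ring carbon, such as an amine or a carboxylic acid, would give a step beyond the scatter.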